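The compounds below may be only part of what the source reports. "The series", "measured", "known", "first", "only" and "open" are said of these compounds alone.

Compound 1 `C[C@H](NC(=O)CN(c1nc(Cl)nc2[nH]cnc12)C1CC1)C(=O)O`: 28.4%
Compound 2 `O=C(O)C[C@H](NC(=O)CN(c1nc(Cl)nc2[nH]cnc12)C1CC1)C(=O)O`: 22%
Compound 3 `CSCC[C@H](NC(=O)CN(c1nc(Cl)nc2[nH]cnc12)C1CC1)C(=O)O`: 5.67%

All three share one core and differ only at the saturated chain carbon two bonds along the chain from an amide-type nitrogen and a carbonyl carbon. In a functional assay on the whole organism (Tail, strain ICR) with Mus musculus as the target, in the tail flick test, with a stated time of 120 min, at a dose of 25 umol/kg by the oral route (a higher number here means a stronger effect of the compound at the dose given, a lower number a weaker effect), compound 1 gives the highest of the three numbers. The step of a number 6.4 percentage points lower from compound 1 to compound 2 (within the scatter) lies within the scatter, so compounds 1 and 2 cannot be ordered against each other; the step of a number 22.7 percentage points lower from compound 1 to compound 3 (beyond the scatter) lies beyond it, as does a number 16.3 percentage points lower from compound 2 to compound 3 (beyond the scatter).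

Compound 4 `C[C@H](NC(=O)CN(c1nc(Cl)nc2[nH]cnc12)C1CC1)C(=O)OCc1ccccc1` is not yet measured. It differs from compound 1 by benzyl in place of hydrogen on an oxygen next to a carbonyl group. Going by the values given here, none of the measured steps touches the oxygen next to the carbonyl group; all three alter the saturated chain carbon, so they give no direct guide to the size or direction of this change. With nothing in the series bearing on it, the expectation for compound 4 in this assay is a step of no settled direction, a number 1.6 percentage points higher from compound 1 to compound 4 (within the scatter), held near the scatter as the central guess but with a wide range. The estimate for compound 4 is 30%, between 10% and 55%.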

Compound 4, a percentage reported as activity, at one dose (the size of the read-out at that dose, not a potency): 36.1%
For compound 4 the middle estimate is 6.1 percentage points below the measured one, within the range that was stated.
By their numbers in this assay, from the lowest: compound 3; then compounds 2, 1 and 4 (each within the scatter of the next, the first and the last beyond it).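

The oxygen next to a carbonyl group is a second point of change in the series, separate from the saturated chain carbon altered in compounds 1, 2 and 3. In this assay, benzyl in place of hydrogen on this oxygen gives a number 7.7 percentage points higher from compound 1 to compound 4 (within the scatter), so compounds 1 and 4 cannot be ordered against each other. The hydrogen of the carboxy group is therefore not needed for a read-out of this size at this dose and time, and nothing available bears on the reason for this result.

Open, from the compounds shown here alone, is whether a methyl ester, an ethyl ester or a primary amide in place of the benzyloxycarbonyl gives a similar read-out. Also open, going by these compounds, is whether benzyloxycarbonyl in place of carboxy on the cores of compounds 2 and 3 would leave the gaps between them unchanged.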